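Replacing the arylamine of compound 1 with a dialkylamine

This account rests on a few compounds, and the source may have more. Where it says the series, first, only, none or still open, it means among the compounds named here.

The series shares one core, seen in compound 1 `COc1cccc(NC2=CC(=O)c3c(nc4n3[C@H]3OC[C@@H](O)[C@H]3OC4)C2=O)c1`, compound 2 `CCc1ccc(NC2=CC(=O)c3nc4n(c3C2=O)[C@H]2OC[C@@H](O)[C@H]2OC4)cc1` and compound 3 `O=C1C=C(NC2CCCCC2)C(=O)c2c1nc1n2[C@H]2OC[C@@H](O)[C@H]2OC1`. In a functional assay on MGC-803 cells (Homo sapiens) for inhibition, read by sulforhodamine B assay (a lower number here means a stronger inhibitor, a higher number a weaker inhibitor), compound 1 gives 1790 nM, and compound 2 gives 1290 nM; the two sit within the scatter of each other, so no order between them is claimed. For compound 3 the assay reports only a limit, > 8000 nM, the limit noted as the limit of > 8000 nM in this assay, at which 1 of the 3 values shown sits.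

Within the data shown here, the one measured step that removes the aromatic ring from the amine, an at least 6.2-fold higher number from compound 2 to compound 3 (0.79 log units; beyond the scatter), weakens inhibition, and its true size is hidden by the limit.

Compound 4 `CCCN(CCC)C1=CC(=O)c2c(nc3n2[C@H]2OC[C@@H](O)[C@H]2OC3)C1=O` is not yet measured. It differs from compound 1 by dipropylamino in place of (3-methoxyphenyl)amino on a double-bonded ring carbon. As in the step to compound 3, the six-membered aromatic ring of carbon only is lost, and the single hydrogen-bond donor goes with it. A weakening of at least the size seen for compound 3 is therefore expected, so compound 4 is estimated at 6000 nM, between 2000 nM and 18000 nM, which is the expected step of a 3.4-fold higher number from compound 1 to compound 4 (0.53 log units; beyond the scatter).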

Compound 4, half-maximal inhibitory concentration: > 16000 nM
Compound 4 ended at the assay's limit; the forecaster's own chance of this, stated with the estimate: 35%; middle value at least 2.6-fold (0.42 log units) from the limit.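

In this assay, dipropylamino on the double-bonded ring carbon gives an at least 8.9-fold higher number from compound 1 to compound 4 (0.95 log units; beyond the scatter), so the loss seen with cyclohexyl also appears with an open-chain dialkylamine that has no hydrogen-bond donor. Compound 4 gives > 16000 nM, which is a limit of the assay and not a number. Compound 3 and compound 4, the two compounds shown without an aromatic ring on the amine, now both sit at limits, while numerical values at this position come only from the arylamines, compound 1 and compound 2.

The two limits do not order compound 3 and compound 4, and the compounds shown do not separate loss of the aromatic ring from loss of the amine hydrogen. A methyl(phenyl)amino group, which keeps the ring without that hydrogen, would bear directly on this question.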